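Removing One Methoxy Group: Does the Cell Toxicity Change?

This account rests on a few compounds, and the source may have more. Where it says the series, first, only, none or still open, it means among the compounds named here.

Measured so far:
Compound 1, `COc1cc(-c2cc(/C=C/C(=O)c3ccc(N)cc3)[nH]n2)cc(OC)c1OC`: 47500 nM
Compound 2, `COc1ccc(-c2cc(/C=C/C(=O)c3ccc(N)cc3)[nH]n2)cc1OC`: 53900 nM
Compound 3, `COc1cc(C(=O)/C=C/c2cc(-c3cc(OC)c(OC)c(OC)c3)n[nH]2)cc(OC)c1OC`: 9510 nM

In a functional assay on MDA-MB-231 cells (Homo sapiens) for inhibition, read by sulforhodamine B assay, with a stated time of 48 h (on this read-out higher numbers stand for lower toxicity in this test and lower numbers for higher toxicity in this test), compound 3 gives 9510 nM, the lowest of the three numbers, and both compound 1 and compound 2 lie well above it. The change from compound 1 to compound 2, (hydrogen in place of methoxy on an aromatic carbon), gave a 1.1-fold higher number from compound 1 to compound 2 (0.05 log units; within the scatter). The difference between the core of compound 3 and the core of compound 1 is not broken down here. Compound 4, `COc1ccc(-c2cc(/C=C/C(=O)c3cc(OC)c(OC)c(OC)c3)[nH]n2)cc1OC`, has not yet been measured; it differs from compound 3 by hydrogen in place of methoxy on an aromatic carbon, the same change at the same place. Because a 1.1-fold higher number from compound 1 to compound 2 (0.05 log units; within the scatter) stayed within the scatter, the step of a 1.1-fold higher number from compound 3 to compound 4 (0.04 log units; within the scatter) is expected to be of similar size. In this assay compound 4 is therefore estimated at 10500 nM, with an expected range from 5000 nM to 22000 nM.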

Compound 4, concentration lethal to 50% of the cells: 55400 nM
For compound 4 the middle estimate is 5.3-fold (0.72 log units) below the measured one; the whole stated range lies below it.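

In this assay, hydrogen in place of methoxy gave a 5.8-fold higher number from compound 3 to compound 4 (0.77 log units; beyond the scatter), so a change that stayed within the scatter on the core of compound 1 did not do so on the core of compound 3. The step therefore did not carry over at one size between these two cores: the same change on two cores in this assay, a 1.1-fold higher number (0.05 log units; within the scatter) from compound 1 to compound 2 and a 5.8-fold higher number (0.77 log units; beyond the scatter) from compound 3 to compound 4, 5.1-fold (0.71 log units) apart, beyond the scatter of two such steps. This rests on a single pair for each core, so it shows that the size of the step differed with the core, but not which part of the core accounts for the difference or what the step would be on any further core.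

The compounds shown leave open how the series would respond if a hydroxy group, a fluorine or a longer ethoxy chain took the place of the methoxy group. They also leave open whether the same contrast between the two cores would appear with any of these replacements.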